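Amide nitrogen methylation across two quinoline-type and pyridine-type cores

The source may report more compounds than this note shows. Statements on the series, on what has been measured and on what is new or still open speak of the compounds shown alone.

Compound 1 `O=C(NCc1cc(C(F)(F)F)cc(C(F)(F)F)c1)c1cnc2ccccc2c1-c1ccccc1` gives 208 nM in an assay on CHO cells for displacement of a labelled ligand from Substance-P receptor (Homo sapiens), with a stated time of 90 min; a lower number here means a stronger inhibitor, a higher number a weaker inhibitor.
Compound 2 `CN(Cc1cc(C(F)(F)F)cc(C(F)(F)F)c1)C(=O)c1cnc2ccccc2c1-c1ccccc1` gives 92 nM in this assay.
Compound 3 `Cc1nc(N2CCN(C)CC2)cc(-c2ccccc2)c1C(=O)NCc1cc(C(F)(F)F)cc(C(F)(F)F)c1` gives 53 nM in this assay.

Compounds 1 and 2 share one core and differ only by methyl in place of hydrogen on an amide-type nitrogen. This change produced a 2.3-fold lower number from compound 1 to compound 2 (0.35 log units; beyond the scatter), a gain that lies beyond the usual scatter of the assay. Compound 3 carries a different core; how the core of compound 3 differs from the core of compound 1 is not broken down here. Compound 3 and compound 2 lie within the scatter of each other, while compound 1 sits further off.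

Compound 4 `Cc1nc(N2CCN(C)CC2)cc(-c2ccccc2)c1C(=O)N(C)Cc1cc(C(F)(F)F)cc(C(F)(F)F)c1` is not yet measured. It differs from compound 3 by methyl in place of hydrogen on an amide-type nitrogen, the same change as that from compound 1 to compound 2, made at the same kind of amide-type nitrogen. If the core of compound 3 responds as the core of compound 1 did, the step is expected to be a 2.1-fold lower number from compound 3 to compound 4 (0.33 log units; beyond the scatter), resting on the size of a 2.3-fold lower number from compound 1 to compound 2 (0.35 log units; beyond the scatter). On that basis compound 4 is estimated at 25 nM, within a range of 10 nM to 70 nM.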

Compound 4, half-maximal inhibitory concentration: 4.8 nM
Estimate against measurement, compound 4: 5.2-fold (0.72 log units) above; the measured number lies below the stated range.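

In this assay, methyl in place of hydrogen on the amide-type nitrogen of the core of compound 3 gave a large gain, an 11-fold lower number from compound 3 to compound 4 (1.04 log units; beyond the scatter). The direction of the change held on both cores, but its size did not carry over from one to the other: the same change on two cores in this assay, a 2.3-fold lower number (0.35 log units; beyond the scatter) from compound 1 to compound 2 and an 11-fold lower number (1.04 log units; beyond the scatter) from compound 3 to compound 4, 4.9-fold (0.69 log units) apart, beyond the scatter of two such steps. The earlier step was therefore a poor guide to the size of the later one, yet these two pairs do not show which feature of the core of compound 3 goes with the larger step, and they set no rule for other cores in this series.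

As far as these compounds go, whether an ethyl group or a longer chain on the same nitrogen would give a lower number than methyl remains open. Also open, from the compounds shown here alone, is how large the step would be on a further core, and whether a third core would sit nearer to the modest step or to the large one.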